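The source may hold more compounds than are shown below. What is called first, only, known or untested is meant among the compounds shown, and "the series" means these compounds.

Compound 1 `COc1cc2c(Oc3ccc(NC(=O)c4nccc(-c5ccccc5)n4)cc3F)ccnc2cc1OCCCN1CCCCC1`: in a functional assay on HT-29 cells (Homo sapiens) for cytotoxicity, read by MTT assay, with a stated time of 72 h (a lower number here means a stronger inhibitor, a higher number a weaker inhibitor), compound 1 gives 260 nM.
Compound 2 `COc1cc2c(Oc3ccc(NC(=O)c4nccc(-c5ccc(F)cc5)n4)cc3F)ccnc2cc1OCCCN1CCCCC1`: in this assay compound 2 gives 120 nM.

For the measured compounds named here, compound 2 holds the lower of the two numbers; the only step, a 2.2-fold lower number from compound 1 to compound 2 (0.34 log units; beyond the scatter), lies beyond the scatter. Compound 3 `COc1cc2c(Oc3ccc(NC(=O)c4nccc(-c5ccc(F)cc5F)n4)cc3F)ccnc2cc1OCCCN1CCCCC1` differs from compound 2 by fluoro in place of hydrogen on an aromatic carbon. Going by the values given here, the single step that bears on this, a 2.2-fold lower number from compound 1 to compound 2 (0.34 log units; beyond the scatter), was modest, and a second fluoro on the same ring need not repeat it; a change within the scatter, or a small further lowering, is expected. The expected step is a 1.2-fold lower number from compound 2 to compound 3 (0.08 log units; within the scatter). Compound 3 is estimated at 100 nM, within 40 nM to 250 nM.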

Compound 3, half-maximal inhibitory concentration: 400 nM
Estimate against measurement, compound 3: 4.0-fold (0.60 log units) below, and the stated range ends below it.
By their numbers in this assay, from the lowest: compound 2; then compounds 1 and 3 (each within the scatter of the next).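

Fluoro on the aromatic carbon ortho to a large group does not repeat the first fluoro: in this assay the new step is a 3.3-fold higher number from compound 2 to compound 3 (0.52 log units; beyond the scatter), opposite in direction to the earlier step. The comparison with the unsubstituted ring, a 1.5-fold higher number from compound 1 to compound 3 (0.19 log units; within the scatter), does not separate 2,4-difluorophenyl from phenyl, so the advantage of 4-fluorophenyl is not kept. Nothing available explains this reversal.

As far as these compounds go, whether the loss is specific to fluoro or extends to other groups at this carbon remains open. Chloro, methoxy or an amine there would test this.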